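The compounds below may be only part of what the source reports. "The series", "measured", "known", "first", "only" and "open" are said of these compounds alone.

Measured in a functional assay for inhibition of sodium/hydrogen exchanger (Oryctolagus cuniculus); on this read-out higher numbers stand for weaker inhibition and lower numbers for stronger inhibition:
compound 1 `Cc1cc(Cl)c(S(C)(=O)=O)cc1C(=O)N=C(N)N` gives 25 nM
compound 2 `Cc1c(C(=O)N=C(N)N)cc(S(C)(=O)=O)c(Cl)c1[N+](=O)[O-]` gives 44 nM
compound 3 `Cc1c(C(=O)N=C(N)N)cc(S(C)(=O)=O)c(C)c1C` gives 55 nM

Compound 1 has the lowest of the three numbers; its gap to compound 2 is within the scatter, its gap to compound 3 lies beyond it. Compound 4 `Cc1cc(-c2ccc(F)cc2)c(S(C)(=O)=O)cc1C(=O)N=C(N)N` departs from compound 1 as follows: 4-fluorophenyl in place of chloro on an aromatic carbon. Among the compounds with values here, no measured step covers a change of this kind. Within the data shown here, the only one-place step known, a 1.8-fold higher number from compound 1 to compound 2 (0.25 log units; within the scatter), concerns a nitro group and is within the scatter. Compound 3 differs from compound 1 in more than one place, so its value gives no clean reading for the present change. The expectation for compound 4 is therefore wide, with a modest weakening as the central guess: a 2.4-fold higher number from compound 1 to compound 4 (0.38 log units; beyond the scatter) is expected. Compound 4 is estimated at 60 nM, range 15 nM to 250 nM.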

Compound 4, half-maximal inhibitory concentration: 36 nM
The estimate for compound 4 lay 1.7-fold (0.22 log units) above the measured number; low and high end bracket the measured number.
By their numbers in this assay, from the lowest: compounds 1, 4, 2 and 3 (each within the scatter of the next, the first and the last beyond it).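

Replacing chloro with 4-fluorophenyl, ortho to a methylsulfonyl group, gives a 1.4-fold higher number from compound 1 to compound 4 (0.16 log units; within the scatter) in this assay. Within the data shown here, no earlier one-place step touched this position, and this one shows that it can carry a group of 7 heavy atoms with an aromatic ring and stay within the scatter of compound 1. Nothing on hand explains why the step is this small. Still open, on these data alone, is whether an amine, a carboxylic acid or an unsubstituted phenyl ring here would also stay within the scatter of compound 1. One aromatic substituent does not set the limits of this position.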